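Removing the methoxy from a potent compound

This account rests on a few compounds, and the source may have more. Where it says the series, first, only, none or still open, it means among the compounds named here.

Values in a functional assay on RKO cells (Homo sapiens) for cytotoxicity, read by resazurin assay, with a stated time of 72 h; on this read-out higher numbers stand for weaker inhibition and lower numbers for stronger inhibition:
- Compound 1 `c1ccc(Nc2nc(-n3cnc4ccccc43)cs2)cc1`: > 100000 nM
- Compound 2 `COc1ccc(Nc2nc(-n3c(C)nc4ccccc43)cs2)cc1`: 25 nM

The entry for compound 1, > 100000 nM, is a limit of the assay and not a number. Within the data shown here, compound 2, at 25 nM, holds the only true number so far. Compound 3 `Cc1nc2ccccc2n1-c1csc(Nc2ccccc2)n1` differs from compound 2 by one change: hydrogen in place of methoxy on an aromatic carbon, so 4-methoxyphenyl becomes phenyl. Among the measured compounds shown here, no measured step shows this change alone, so any forecast in this assay is uncertain. The expected 20-fold higher number from compound 2 to compound 3 (1.30 log units; beyond the scatter) is a clear weakening, well beyond the scatter. The estimate for compound 3 is 500 nM, with an expected range of 50 nM to 20000 nM.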

Compound 3, half-maximal inhibitory concentration: 40000 nM
The estimate for compound 3 lay 80-fold (1.90 log units) below the measured number; measured number outside the range, above it.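

Going from 4-methoxyphenyl to phenyl, with everything else held the same, gives a 1600-fold higher number from compound 2 to compound 3 (3.20 log units; beyond the scatter), so nearly all the potency of compound 2 is lost with this one group. On the phenyl compounds, methyl in place of hydrogen on the shared core gives an at least 2.5-fold lower number from compound 1 to compound 3 (0.39 log units; beyond the scatter). Compound 1 holds a limit of the assay and not a number, so that step has no upper size: the limit of > 100000 nM in this assay, at which 1 of the 3 values shown sits.

From the compounds shown here alone, what a hydroxyl, an ethoxy or an amine would give at this same place remains open. So does whether methoxy still works without that methyl.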